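The source may report more compounds than this note shows. Statements on the series, on what has been measured and on what is new or still open speak of the compounds shown alone.

Working notes on the series. Compound 1 `CCc1cccc(C[C@H](O)/C=C/[C@H]2COC(=O)N2CCSCCCC(=O)O)c1` is the starting point here. In an assay on CHO cells for displacement of a labelled ligand from prostaglandin E2 receptor EP2 subtype (Mus musculus), read by scintillation counting, with a stated time of 60 min (on this read-out higher numbers stand for weaker inhibition and lower numbers for stronger inhibition), compound 1 gives > 10000 nM, which is a limit of the assay and not a number. It therefore stands at the limit of > 10000 nM in this assay, at which 2 of the 3 values shown sit; no numerical position within the set can be assigned to it. Among the compounds with values here, compound 2 `CCCc1cccc(C[C@H](O)/C=C/[C@H]2CCC(=S)N2CCCCCCC(=O)O)c1` is the one member with a measured number: in this assay compound 2 gives 6800 nM. Compound 3 `CCc1cccc(C[C@H](O)/C=C/[C@H]2CSC(=O)N2CCSCCCC(=O)O)c1` sits at the limit as well: in this assay compound 3 gives > 10000 nM, a limit of the assay rather than a number. Within the data shown here, no two measured compounds differ in only one place, so no measured step is available to calibrate the change below.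

Compound 4 `O=C(O)CCCSCCN1C(=O)OC[C@@H]1/C=C/[C@@H](O)Cc1cccc(Cl)c1` is not yet measured. It differs from compound 1 as follows: chloro in place of ethyl on an aromatic carbon. With compound 1 at the limit and no measured step of this kind in the set, the expected step in this assay is none beyond the scatter, with weak inhibition the most likely outcome for compound 4 as well. Compound 4 is expected to give 12000 nM in this assay, within 3000 nM to 40000 nM, which means an expected step that the limit leaves unreadable from compound 1 to compound 4.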

Compound 4, inhibition constant: > 10000 nM
Compound 4 ended at the assay's limit; the forecaster's own chance of this, stated with the estimate: 65%; the middle value does not contradict the limit.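

Compound 1 and compound 4 both sit at a limit of the assay, so chloro in place of ethyl yields no readable step in this assay: the limit of > 10000 nM in this assay, at which 3 of the 4 values shown sit. The compounds shown leave open how compound 1 and compound 4 actually compare, and whether this change on the aromatic carbon alters inhibition at all.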